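A Longer Chain: From Compound 3 to Compound 4

A few compounds are considered here, and "the series" means these few. Any claim that something is new, unique, unknown or untested is made for them only; others in the source may bear on it.

Three compounds have so far been measured in a functional assay on SMMC-7721 cells (Homo sapiens) for cytotoxicity, read by MTT assay, with a stated time of 72 h; a lower number here means a stronger inhibitor, a higher number a weaker inhibitor:

Compound 1, `[O-][n+]1nc(NCOC2CCCCC2)[n+]([O-])c2ccccc21`: 28200 nM
Compound 2, `[O-][n+]1nc(NCOCc2ccccc2)[n+]([O-])c2ccccc21`: 20100 nM
Compound 3, `CCOCNc1n[n+]([O-])c2ccccc2[n+]1[O-]`: 27100 nM

All three share one core and differ only in the group on the oxygen on a saturated carbon. Compound 3 has the second highest of the three numbers, with compound 1 nearest to it and compound 2 furthest away, yet every step among them stays within the scatter: a 1.0-fold lower number from compound 1 to compound 3 (0.02 log units; within the scatter), a 1.3-fold higher number from compound 2 to compound 3 (0.13 log units; within the scatter) and a 1.4-fold lower number from compound 1 to compound 2 (0.15 log units; within the scatter). Cyclohexyl, benzyl and ethyl at this oxygen thus give numbers that cannot be told apart in this assay.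

Compound 4, `CCCCCCCOCNc1n[n+]([O-])c2ccccc2[n+]1[O-]`, is the next compound. It differs from compound 3 by pentyl in place of hydrogen on a saturated chain carbon, two bonds along the chain from an oxygen on a saturated carbon. Going by the values given here, no measured step lengthens a chain at this carbon, so the only guide is that the three changes at the same oxygen, a 1.0-fold lower number from compound 1 to compound 3 (0.02 log units; within the scatter) and a 1.3-fold higher number from compound 2 to compound 3 (0.13 log units; within the scatter) among them, all lay within the scatter. A step within the scatter is therefore expected in this assay, with no direction favoured. The expected step of a 1.1-fold lower number from compound 3 to compound 4 (0.04 log units; within the scatter) reflects this. Compound 4 is estimated at 25000 nM, in a range from 10000 nM to 60000 nM.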

Compound 4, half-maximal inhibitory concentration: 7030 nM
The estimate for compound 4 lay 3.6-fold (0.55 log units) above the measured number, and the stated range ends above it.
By their numbers in this assay, from the lowest: compound 4; then compounds 2, 3 and 1 (each within the scatter of the next).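

In this assay this oxygen no longer looks indifferent to what it carries: pentyl in place of hydrogen on a saturated chain carbon, two bonds along the chain from an oxygen on a saturated carbon, gives a 3.9-fold lower number from compound 3 to compound 4 (0.59 log units; beyond the scatter) and so does what no change among compound 1, compound 2 and compound 3 did. Compound 4 also separates from the two compounds with ring-bearing groups, with a 2.9-fold lower number from compound 2 to compound 4 (0.46 log units; beyond the scatter) and a 4.0-fold lower number from compound 1 to compound 4 (0.60 log units; beyond the scatter) in the same direction, so it alone stands apart and has the lowest number of the four, though each of these steps is only modest. The link between chain length and a lower number rests on a single lengthening, ethyl to heptyl, and is therefore one step rather than a trend.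

On these data alone, whether the number falls gradually through propyl, butyl and pentyl, and whether a chain longer than heptyl, a branched chain or a chain ending in an amine or a hydroxyl would lower it further, remains open. Nothing available here accounts for the lower number of compound 4.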